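The source may report more compounds than this note shows. Statements on the series, on what has been measured and on what is new or still open speak of the compounds shown alone.

Measured so far in a functional assay on the whole organism (strain NMRI) with Mus musculus as the target, in the maximal electroshock model, with a stated time of 30 min; a lower number here means that less compound is needed, a higher number that more compound is needed for the effect:
Compound 1, `C=CCOCC(N)C(=O)NCc1ccccc1`, gives 45 mg/kg.
Compound 2, `NCC(N)C(=O)NCc1ccccc1`, gives only a limit, > 68 mg/kg.
Compound 3, `N[C@H](CCO)C(=O)NCc1ccccc1`, gives only a limit, > 160 mg/kg.

Compound 2 stands at a limit of this assay, so its number is not known; of the three values shown, one further value is also a limit. The change from compound 2 to compound 4, `C#CCOCC(N)C(=O)NCc1ccccc1`, is propargyloxy in place of amino on a saturated chain carbon, two bonds along the chain from an amine nitrogen and a carbonyl carbon. Among the measured compounds shown here, one measured step bears on it: an at least 1.5-fold higher number from compound 1 to compound 2 (0.17 log units; that floor lies within the scatter), a change which read in reverse replaces amino with allyloxy. The step from compound 2 to compound 3 is a step that the two limits leave unreadable from compound 2 to compound 3 and gives no guidance. Putting propargyloxy in place of amino resembles that reverse reading, so compound 4 is expected to need roughly as much as compound 1 in this assay. The floor of the measured step rests on compound 2 sitting at the limit of > 68 mg/kg in this assay, at which 1 of the 3 values shown sits. The expected step is therefore an at least 1.3-fold lower number from compound 2 to compound 4 (0.13 log units; that floor lies within the scatter), toward a lower number. Compound 4 is estimated at 50 mg/kg, between 25 mg/kg and 120 mg/kg.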

Compound 4, dose for half-maximal effect: 46 mg/kg
The estimate for compound 4 lay 1.1-fold (0.04 log units) above the measured number, within the range that was stated.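

What compound 4 adds is that a second ether at this carbon behaves like the first in this assay. With ethynyl in place of vinyl on a saturated chain carbon bound to an oxygen on a saturated carbon, the result is a 1.0-fold higher number from compound 1 to compound 4 (0.01 log units; within the scatter), so the two unsaturated ends cannot be told apart here. Against the amino group, propargyloxy gives an at least 1.4-fold lower number from compound 2 to compound 4 (0.16 log units; that floor lies within the scatter), and this size is only a floor because compound 2 stands at a limit and not at a number: the limit of > 68 mg/kg in this assay, at which 1 of the 4 values shown sits.

From the compounds shown here alone, it remains open whether the triple or double bond is needed at all, since a saturated propoxy or a shorter methoxy at the same carbon would test this against compound 1 at 45 mg/kg. Going by these compounds, how far a longer ether chain or a carboxylic acid at this carbon would carry the result also stays unknown.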